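Chloro to Methyl on an Already Stable Compound

The source may report more compounds than this note shows. Statements on the series, on what has been measured and on what is new or still open speak of the compounds shown alone.

Compound 1 (`CC(C)(C)NCc1cc(Cl)cc(Nc2nc3cc(F)c(F)cc3n2Cc2ccc(C(F)(F)F)cc2)c1O`) is the starting point, and its stability is measured in an ADME assay on microsomes from liver (Rattus norvegicus) for metabolic stability, read by LC-MS, with a stated time of 30 min, tested at 1 uM; on this read-out lower numbers stand for a less stable compound and higher numbers for a more stable compound. For the measured compounds named here, in this test compound 1 gives 94% remaining, the only exact number available and a high reading on the scale. The one other result comes from compound 2 (`CCNCc1cc(Cl)cc(Nc2nc3cc(F)c(F)cc3[nH]2)c1O`), a relative that differs from compound 1 in more than one place. Compound 2 reads > 99% as a limit of the assay and not as a number.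

Compound 3 (`Cc1cc(CNC(C)(C)C)c(O)c(Nc2nc3cc(F)c(F)cc3n2Cc2ccc(C(F)(F)F)cc2)c1`) differs from compound 1 in one place, with methyl in place of chloro on an aromatic carbon, para to a hydroxy group (methyl in place of chloro on an aromatic carbon). Going by the values given here, no measured pair differs in one place only, so nothing here gives the size of such a swap directly. With compound 1 at 94% little room remains upward, so a modest fall is expected, perhaps not much beyond the usual scatter. The expected step of a number 8 percentage points lower from compound 1 to compound 3 (within the scatter) is therefore small and downward. In this assay the estimate for compound 3 is 86% within an expected range of 68% to 98% remaining.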

Compound 3, percent of the compound remaining: 89%
Beside the measured number, compound 3's estimate is 3 percentage points below it; low and high end bracket the measured number.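

This is the only pair shown that differs in one place, so the swap of chloro for methyl, para to a hydroxy group, can now be sized in this assay: the step is a number 5 percentage points lower from compound 1 to compound 3 (within the scatter). In this one pair, the two groups cannot be told apart at this position, and both compounds give high readings on the scale. Compound 2 holds the only reading at the very top of the scale, a limit of the assay and not a number, so a small effect of this swap could be hard to see this close to that top: the limit of > 99% in this assay, at which 1 of the 3 values shown sits.

Still open, going by these compounds, is whether an amine, a carboxylic acid or a longer chain at this same position, para to the hydroxy group, would give a reading clearly apart from those of the chloro and methyl compounds. Also open, on these data alone, is whether methyl in place of chloro would give a similar step on a less stable relative, where the scale leaves more room to show a change.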